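Chloro for fluoro on a cyclopropylmethoxy compound

The source may hold more compounds than are shown below. What is called first, only, known or untested is meant among the compounds shown, and "the series" means these compounds.

In an ADME assay on the whole organism (plasma, Mus musculus, strain CD1), read by LC-MS, with a stated time of 24 h (a lower number here means a smaller unbound share, a higher number a larger unbound share of the compound), compound 1 (`O=C(O)Cn1nc(Cc2nc3cc(Cl)c(OCC(F)F)cc3[nH]2)c2ccccc2c1=O`) gives 0.038, compound 2 (`CCOc1cc2[nH]c(Cc3nn(CC(=O)O)c(=O)c4ccccc34)nc2cc1Cl`) gives 0.051 and compound 3 (`O=C(O)Cn1nc(Cc2nc3cc(F)c(OCC4CC4)cc3[nH]2)c2ccccc2c1=O`) gives 0.026, so compound 3 lies within the scatter of both others. Compound 4 (`O=C(O)Cn1nc(Cc2nc3cc(Cl)c(OCC4CC4)cc3[nH]2)c2ccccc2c1=O`) differs from compound 3 by one exchange: chloro in place of fluoro on an aromatic carbon. Among the measured compounds shown here, no measured step makes this exchange. The only one available, a 1.3-fold higher number from compound 1 to compound 2 (0.13 log units; within the scatter), lies on the chain bound to oxygen, stays within the scatter and bears on it only weakly. No shift beyond the scatter is therefore expected in this assay, and the expected step is small, a 1.1-fold lower number from compound 3 to compound 4 (0.03 log units; within the scatter). For compound 4 the estimated value is 0.024, with an expected range of 0.012 to 0.045.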

Compound 4, unbound fraction: 0.012
Beside the measured number, compound 4's estimate is 2.0-fold (0.30 log units) above it; measured number inside the range.
By their numbers in this assay, from the lowest: compound 4; then compounds 3, 1 and 2 (each within the scatter of the next).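

In this assay the halogen on this aromatic carbon, ortho to the cyclopropylmethoxy group, moves the number beyond the scatter: chloro in place of fluoro gives a 2.2-fold lower number from compound 3 to compound 4 (0.34 log units; beyond the scatter) at this position. With chloro held there, the chain on the oxygen also tells compounds apart, since cyclopropyl in place of methyl gives a 4.3-fold lower number from compound 2 to compound 4 (0.63 log units; beyond the scatter) and cyclopropyl in place of difluoromethyl gives a 3.2-fold lower number from compound 1 to compound 4 (0.50 log units; beyond the scatter) on that chain.

From the compounds shown here alone, how bromo, trifluoromethyl or an amine would read on this carbon, and whether chloro for fluoro gives a similar step with another chain, stays open. Nothing at hand gives a cause for these steps.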